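This account rests on a few compounds, and the source may have more. Where it says the series, first, only, none or still open, it means among the compounds named here.

Three closely related compounds form the starting point, all judged by a functional assay on MDA-MB-231 cells (Homo sapiens) for antiproliferative activity, with a stated time of 72 h (on this read-out lower numbers stand for an effect already at smaller amounts and higher numbers for an effect only at larger amounts of compound), as the test. Compound 1 `O=C(O)c1ccc(N(Cc2ccc(C3CCCCC3)cc2)C(=O)[C@H]2CCN2S(=O)(=O)c2c(F)c(F)c(F)c(F)c2F)c(F)c1` gives > 10000 nM in this assay here, and this is a limit of the assay, not a number. Compound 2 `O=C1OCc2cc(N(Cc3ccc(C4CCCCC4)cn3)C(=O)[C@H]3CCN3S(=O)(=O)c3c(F)c(F)c(F)c(F)c3F)ccc21` gives a real number, 900 nM in the same read-out. As far as these compounds go, compound 3 `CONC(=O)c1ccc(N(Cc2ccc(C3CCCCC3)cn2)C(=O)[C@H]2CCN2S(=O)(=O)c2c(F)c(F)c(F)c(F)c2F)c(F)c1` has no number to stand on: its entry reads "not determined" (no result reported) in this assay, so its place relative to the other two is unknown.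

The next compound is compound 4 `NC(=O)c1ccc(N(Cc2ccc(C3CCCCC3)cn2)C(=O)[C@H]2CCN2S(=O)(=O)c2c(F)c(F)c(F)c(F)c2F)cc1O`, and the change sits on an amide-type nitrogen: 4-carbamoyl-3-hydroxyphenyl in place of 2-fluoro-4-(methoxycarbamoyl)phenyl on an amide-type nitrogen. Put simply, 4-carbamoyl-3-hydroxyphenyl comes in place of 2-fluoro-4-(methoxycarbamoyl)phenyl, and the rest of the molecule stays the same.

Without a value for compound 3, no step can be read from it. The nearest guide is compound 2 at 900 nM, which keeps the same remainder of the molecule and differs only in the group on that nitrogen. Against that guide, a modest shift towards higher numbers in this assay is expected, meaning a somewhat weaker effect. For compound 4 the estimated value is 2500 nM, with an expected range from 700 nM to 10000 nM in this test.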

Compound 4, half-maximal effective concentration: 2900 nM
Beside the measured number, compound 4's estimate is 1.2-fold (0.06 log units) below it, and the stated range covers the measured number.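

For the compounds shown here, on the amide-type nitrogen, 4-carbamoyl-3-hydroxyphenyl still gives a real number in this assay, and the one comparison that can be read is a 3.2-fold higher number from compound 2 to compound 4 (0.51 log units; beyond the scatter) and it shows that this place responds to the group it carries, with a modest loss of effect. The two groups hold the same count of heavy atoms, yet the numbers differ, so that count alone does not settle the result at this place. Compound 3 has no value, so no step from it can be read, and nothing measured here gives a reason for the step.

The compounds shown leave open which part of the change matters, since the ring system, the carbamoyl and the hydroxyl all differ from compound 2 in a single swap. A nitrile in place of the carbamoyl, or an amine in place of the hydroxyl, with the rest of compound 4 kept the same, would help to show which feature of this group the number in this assay follows.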